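A few compounds are considered here, and "the series" means these few. Any claim that something is new, unique, unknown or untested is made for them only; others in the source may bear on it.

In a functional assay, read by spectrophotometry, with a stated time of 2 h, tested at 2.5 mg/mL (on this read-out higher numbers stand for a stronger effect at the one concentration tested and lower numbers for a weaker effect), compound 1 `CC(C)[C@@H]1CC[C@@H](C)C[C@@]12N(C)C(=O)[C@@H]1[C@H]3C(=O)N(C)C(=O)[C@H]3ON12` gives 70.3%. Going by the values given here, compound 2 `CC(C)[C@@H]1CC[C@@H](C)C[C@@]12N(C)C(=O)[C@@H]1[C@H]3C(=O)N(c4ccc(Cl)cc4)C(=O)[C@H]3ON12` gives 60.1% in this assay, the lower of the two numbers measured; the only measured step, a number 10.2 percentage points lower from compound 1 to compound 2 (beyond the scatter), concerns the group on the amide-type ring nitrogen. Compound 3 `COc1ccc(N2C(=O)[C@H]3[C@H](ON4[C@@H]3C(=O)N(C)[C@@]43C[C@H](C)CC[C@H]3C(C)C)C2=O)cc1` differs from compound 2 in a different place, by methoxy in place of chloro on an aromatic carbon. Among the compounds with values here, no measured step covers an exchange on the aromatic ring, so nothing here argues for a shift beyond the scatter, and the expected step is a number 0.1 percentage points lower from compound 2 to compound 3 (within the scatter). Compound 3 is therefore estimated at 60%, within a range from 45% to 75%.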

Compound 3, a percentage reported as activity, at one concentration (the size of the read-out at that concentration, not a potency): 71.5%
The estimate for compound 3 lay 11.5 percentage points below the measured number; the measured number falls inside the stated range.
By their numbers in this assay, from the lowest: compound 2; then compounds 1 and 3 (each within the scatter of the next).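

On the aryl group at the amide-type ring nitrogen, the substituent on the aromatic carbon affects the read-out in this assay, with methoxy in place of chloro giving a number 11.4 percentage points higher from compound 2 to compound 3 (beyond the scatter). An aryl group at this nitrogen therefore does not by itself lower the number, since 4-methoxyphenyl in place of methyl gives a number 1.2 percentage points higher from compound 1 to compound 3 (within the scatter), within the scatter. Nothing available explains the difference between chloro and methoxy. Open, from the compounds shown here alone, is how an amine or a carboxylic acid on this aromatic carbon would read. Also open, going by these compounds, is how a longer chain in place of methyl on this nitrogen would read.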